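Exchanging the hydrazone end group on a shared core

The compounds below may be only part of what the source reports. "The series", "measured", "known", "first", "only" and "open" are said of these compounds alone.

Of the compounds shown here, two built on one shared core have been tested in an assay for inhibition of Amine oxidase [flavin-containing] B (Bos taurus), read by fluorescence, with a stated time of 60 min; a higher number here means a weaker inhibitor, a lower number a stronger inhibitor. Compound 1 `O=C(Cn1c(=O)c(Cc2ccccc2)nc2ccccc21)N/N=C/c1ccccc1` gives 880000 nM in this assay. Compound 2 `C/C(=N\NC(=O)Cn1c(=O)c(Cc2ccccc2)nc2ccccc21)c1ccc(O)cc1` gives 980000 nM in this assay. These two numbers sit within the scatter of each other, so compound 2 stands level with compound 1 on the evidence so far. The step of a 1.1-fold higher number from compound 1 to compound 2 (0.05 log units; within the scatter) is nothing beyond the scatter.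

Compound 3 `O=C(Cn1c(=O)c(Cc2ccccc2)nc2ccccc21)N/N=C1/C(=O)Nc2ccccc21` has not yet been measured. It differs from compound 2 in one place: a group of 11 heavy atoms (8 carbon, 2 nitrogen, 1 oxygen; one five-membered non-aromatic ring with 1 hetero atom, one six-membered aromatic ring of carbon only) in place of a group of 10 heavy atoms (8 carbon, 1 nitrogen, 1 oxygen; one six-membered aromatic ring of carbon only), on an amide-type nitrogen. Within the data shown here, the only step seen so far in this assay, a 1.1-fold higher number from compound 1 to compound 2 (0.05 log units; within the scatter), is an exchange on this same amide-type nitrogen and left the number essentially where it was. That step bears on the present change only loosely, since the group entering compound 3 brings a five-membered non-aromatic ring that neither measured compound carries. With no step beyond the scatter on this nitrogen, the expectation for compound 3 is a change of a 1.1-fold lower number from compound 2 to compound 3 (0.04 log units; within the scatter), that is none beyond the scatter. Compound 3 is therefore estimated at 900000 nM, with a range from 300000 nM to 3000000 nM.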

Compound 3, half-maximal inhibitory concentration: 96000 nM
Compound 3: middle estimate off by 9.4-fold (0.97 log units), on the high side; the whole stated range lies above it.
By their numbers in this assay, from the lowest: compound 3; then compounds 1 and 2 (each within the scatter of the next).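

In this assay, this amide-type nitrogen proved sensitive to what it carries: the two earlier end groups left the number unchanged within the scatter, but the group with the five-membered non-aromatic ring gives a 10-fold lower number from compound 2 to compound 3 (1.01 log units; beyond the scatter) and a 9.2-fold lower number from compound 1 to compound 3 (0.96 log units; beyond the scatter). Compound 3 is thus the strongest inhibitor of the three, and the size of the step does not follow the simple counts, since the entering group has the same number of hydrogen-bond donors and acceptors as the group it replaces in compound 2 and only one more heavy atom. No measurement available here explains why this group lowers the number.

The compounds shown cannot separate the contributions of the five-membered ring, its ring nitrogen and its second double bond outside aromatic rings, so an open-chain amide end group would be an informative comparison. They also leave open whether the six-membered aromatic ring of the entering group tolerates a substituent such as a methyl group, a chlorine atom or an amine, and whether the lower number holds on a different core.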